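Methyl in Place of Hydrogen on an Amide-Type Nitrogen

The source may report more compounds than this note shows. Statements on the series, on what has been measured and on what is new or still open speak of the compounds shown alone.

Compound 3 `Cc1ccc(OCc2ccccc2)c(C(C)NC(=O)NS(=O)(=O)c2ccccc2)c1` was examined in a functional assay on thoracic aorta (Rattus norvegicus, strain Wistar), with a stated time of 15 min; a lower number here means that less compound is needed, a higher number that more compound is needed for the effect. In this assay compound 3 gives only a limit, > 200000 nM, and the limit of > 200000 nM in this assay, at which 1 of the 3 values shown sits, marks where that value sits. Two related compounds already carry a methyl on the same nitrogen. Compound 1 `Cc1ccc(S(=O)(=O)N(C)C(=O)NC(C)c2cc(C)ccc2OCc2ccccc2)cc1` gives 181000 nM in this assay. Compound 2 `CC(NC(=O)N(C)S(=O)(=O)c1ccccc1)c1cc(Br)ccc1OCc1ccccc1` gives 60300 nM in this assay. Within the data shown here, no step between measured compounds that differ in a single place is available, so the bearing of the methyl can only be read from these two numbers. Compound 4 `Cc1ccc(OCc2ccccc2)c(C(C)NC(=O)N(C)S(=O)(=O)c2ccccc2)c1` is the unmeasured analogue; the change from compound 3 is methyl in place of hydrogen on an amide-type nitrogen. Because compound 1 gives 181000 nM and compound 2 gives 60300 nM, both with the methyl in place, compound 4 is expected to show a step of an at least 1.6-fold lower number from compound 3 to compound 4 (0.22 log units; that floor lies within the scatter) toward less compound being needed, beyond the usual scatter. Compound 4 is accordingly estimated at 120000 nM in this assay, with a range from 40000 nM to 300000 nM.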

Compound 4, half-maximal effective concentration: 68200 nM
The estimate for compound 4 lay 1.8-fold (0.25 log units) above the measured number; low and high end bracket the measured number.
By their numbers in this assay, from the lowest: compounds 2 and 4 (each within the scatter of the next); then compound 1. At a limit, above all of these: compound 3.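

In this assay the methyl on the amide-type nitrogen now has a direct reading (a single change from its hydrogen parent), and it gives an at least 2.9-fold lower number from compound 3 to compound 4 (0.46 log units; beyond the scatter) in the direction of less compound being needed. That size is only a floor, as compound 3 gives a limit and not a number: the limit of > 200000 nM in this assay, at which 1 of the 4 values shown sits. With the methyl on that nitrogen held constant, the aromatic carbon can now be read too: methyl and bromo there are not told apart (see a 1.1-fold higher number from compound 2 to compound 4 (0.05 log units; within the scatter)), whereas removing the methyl from the other aromatic carbon counts for more (see a 2.7-fold lower number from compound 1 to compound 4 (0.42 log units; beyond the scatter)).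

On these data alone, how large the true step from the hydrogen is remains open. So does whether an ethyl group or a longer chain on that nitrogen would carry the same step or a different one.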